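Swapping the Amide Aryl Ring: Thiazole to Pyridine

A few compounds are considered here, and "the series" means these few. Any claim that something is new, unique, unknown or untested is made for them only; others in the source may bear on it.

Measured so far:
compound 1 `O=C(Nc1ccc(Cl)c(-c2nnc3c(Cl)cccn23)c1)c1ccccn1` — 79000 nM
compound 2 `Cc1nc(C(=O)Nc2ccc(Cl)c(-c3nnc4c(Cl)cccn34)c2)cs1` — 74300 nM

In a functional assay on U-251 cells (Homo sapiens) for antiproliferative activity, read by MTT assay, with a stated time of 72 h (a higher number here means a weaker inhibitor, a lower number a stronger inhibitor), compound 1 gives 79000 nM and compound 2 gives 74300 nM. Among the measured compounds shown here, the step of a 1.1-fold lower number from compound 1 to compound 2 (0.03 log units; within the scatter) lies within the scatter, so compound 2 stands together with compound 1 on the numbers so far. Compound 3 `O=C(Nc1ccc(Cl)c(-c2nnc3c(Cl)cccn23)c1)c1cccnc1` is not yet measured; it differs from compound 2 by pyridin-3-yl in place of 2-methyl-1,3-thiazol-4-yl on a carbonyl carbon. For the measured compounds named here, the only step on record, a 1.1-fold lower number from compound 1 to compound 2 (0.03 log units; within the scatter), exchanged one aromatic ring for another on the same carbonyl carbon and left the number essentially unchanged, so a second exchange of this kind is expected to do the same. The expected step is a 1.0-fold higher number from compound 2 to compound 3 (0.00 log units; within the scatter), within the scatter. Compound 3 is therefore estimated at 75000 nM, with a range from 30000 nM to 160000 nM.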

Compound 3, half-maximal inhibitory concentration: > 100000 nM
Compound 3 ended at the assay's limit; the forecaster's own chance of this, stated with the estimate: 25%; middle value at least 1.3-fold (0.12 log units) from the limit.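

Compound 3 gives a limit, not a number: the limit of > 100000 nM in this assay, at which 1 of the 3 values shown sits. The two steps to it are an at least 1.3-fold higher number from compound 2 to compound 3 (0.12 log units; that floor lies within the scatter) and an at least 1.2-fold higher number from compound 1 to compound 3 (0.10 log units; that floor lies within the scatter), so these floors do not separate compound 3 from the others, and the true gaps may be small or large. What this adds is a third aromatic ring on the carbonyl carbon, and again no low number appears.

On these data alone, how far compound 3 truly lies from compound 1 and compound 2 stays open. So does whether a saturated piperidine ring, or a pyridine ring carrying an amine or a carboxylic acid, would bring the number down.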